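The source may hold more compounds than are shown below. What is called first, only, known or untested is meant among the compounds shown, and "the series" means these compounds.

In a functional assay on the whole organism for inhibition, with Mus musculus as the target (a lower number here means that less compound is needed, a higher number that more compound is needed for the effect), compound 3 `CN1Cc2c(NC(=O)OCc3ccccc3)cccc2C(c2ccccc2)C1` gives about 15 mg/kg, the higher of the two actual numbers in the series, while compound 2 `CCOC(=O)Nc1cccc2c1CN(C)CC2c1ccccc1` gives 3.2 mg/kg. Compound 1 `CCCNC(=O)Nc1cccc2c1CN(C)CC2c1ccccc1` reaches only a limit, > 80 mg/kg. Compound 4 `CCNCCC(=O)Nc1cccc2c1CN(C)CC2c1ccccc1` has 2-(ethylamino)ethyl in place of benzyloxy on a carbonyl carbon. Going by the values given here, no measured step makes this change. The closest guides are an at least 25-fold lower number from compound 1 to compound 2 (1.39 log units; beyond the scatter) and an at least 5.3-fold lower number from compound 1 to compound 3 (0.72 log units; beyond the scatter), both replacing propylamino on a carbonyl carbon, together with a 4.7-fold higher number from compound 2 to compound 3 (0.67 log units; beyond the scatter). Compound 4, like compound 1, lacks an oxygen on the carbonyl carbon, so a modest rise in the number is expected. The expected change is a 2.3-fold higher number from compound 3 to compound 4 (0.37 log units; beyond the scatter). Compound 4 is estimated at 35 mg/kg, within 8 mg/kg to 120 mg/kg.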

Compound 4, dose for half-maximal effect: > 200 mg/kg
Compound 4 ended at the assay's limit; the forecaster's own chance of this, stated with the estimate: 35%; middle value at least 5.7-fold (0.75 log units) from the limit.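

In this assay compound 4 gives > 200 mg/kg, which is a limit and not a number. On the carbonyl carbon, 2-(ethylamino)ethyl costs far more than the benzyloxy or ethoxy groups it replaces: an at least 13-fold higher number from compound 3 to compound 4 (1.12 log units; beyond the scatter), and an at least 62-fold higher number from compound 2 to compound 4 (1.79 log units; beyond the scatter). Compound 1 and compound 4, the two without an oxygen on the carbonyl carbon, both end at limits, so the step between them cannot be read.

The compounds shown do not separate the effect of the chain's amine nitrogen from the loss of that oxygen. A plain butyl chain on the carbonyl carbon would test this.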